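The compounds below may be only part of what the source reports. "The series", "measured", "known", "first", "only" and "open" are said of these compounds alone.

Of the compounds shown here, three sharing one core have been measured in a functional assay on A20 cells (Mus musculus) for inhibition, with stated times of 1 h, 16 h and 24 h; a higher number here means a weaker inhibitor, a lower number a stronger inhibitor. Compound 1 (`N#CC1(NC(=O)[C@@H]2C[C@@H](S(=O)(=O)c3ccccc3)C[C@H]2C(=O)N2CCOCC2)CC1`), with morpholin-4-yl on a carbonyl carbon, gives 12 nM. Compound 2 (`N#CC1(NC(=O)[C@@H]2C[C@@H](S(=O)(=O)c3ccccc3)C[C@H]2C(=O)N2CCCCC2)CC1`), with piperidin-1-yl at that place, gives 5 nM, a modest change: a 2.4-fold lower number from compound 1 to compound 2 (0.38 log units; beyond the scatter). Compound 3 (`N#CC1(NC(=O)[C@@H]2C[C@@H](S(=O)(=O)c3ccccc3)C[C@H]2C(=O)N2CCNCC2)CC1`), with piperazin-1-yl there, gives 1340 nM, the highest number of the three and so the weakest inhibitor. Its separation from the others is large: a 110-fold higher number from compound 1 to compound 3 (2.05 log units; beyond the scatter) and a 270-fold higher number from compound 2 to compound 3 (2.43 log units; beyond the scatter).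

Compound 4 (`N#CC1(NC(=O)[C@@H]2C[C@@H](S(=O)(=O)c3ccccc3)C[C@H]2C(=O)N2CCC(O)CC2)CC1`) has 4-hydroxypiperidin-1-yl in place of piperazin-1-yl on a carbonyl carbon. Going by the values given here, no measured compound carries the hydroxy group, so no step isolates its effect. The closest guides are the two large steps to compound 3, read in reverse, with the modest step between compound 1 and compound 2 showing how close those two lie. Among these three compounds, only compound 3, at 1340 nM, has a second ring nitrogen, and compound 4 has none. Compound 4 is therefore expected to sit near compound 1 and compound 2, which would be a large move towards a lower number. The expected change is an 89-fold lower number from compound 3 to compound 4 (1.95 log units; beyond the scatter). Compound 4 is estimated at 15 nM, with an expected range from 4 nM to 70 nM.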

Compound 4, half-maximal inhibitory concentration: 371 nM
Compound 4: the middle estimate sits 25-fold (1.39 log units) below what was measured; measured number outside the range, above it.
By their numbers in this assay, from the lowest: compound 2; then compound 1; then compound 4; then compound 3.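

In this assay, hydroxy in place of hydrogen on a saturated ring carbon is a large step on its own (a 74-fold higher number from compound 2 to compound 4 (1.87 log units; beyond the scatter)), so a second ring nitrogen is not the only feature at this position that goes with a high number: compound 4 has no such nitrogen and still lies far from compound 2. The step from morpholin-4-yl is also large (a 31-fold higher number from compound 1 to compound 4 (1.49 log units; beyond the scatter)), whereas the step from piperazin-1-yl is only modest (a 3.6-fold lower number from compound 3 to compound 4 (0.56 log units; beyond the scatter)), which places compound 4 much nearer to compound 3 than to the other two. Oxygen on this group therefore gives no single outcome, since it goes with a low number as a ring member in compound 1 and with a much higher one as the hydroxy of compound 4.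

Nothing available here gives a reason for these large steps. The compounds shown leave open whether a methoxy group or a fluorine atom in place of that hydroxy would stay close to compound 2 or fall close to compound 4.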